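Swapping bromo for cyclopropyl on a kinase-binding core

This account rests on a few compounds, and the source may have more. Where it says the series, first, only, none or still open, it means among the compounds named here.

Measured compounds:
Compound 1 `NS(=O)(=O)c1ccc(CNc2nc(Nc3cccc(NC(=O)N4CCCC4)c3)ncc2Br)cc1`: 6170 nM
Compound 2 `NS(=O)(=O)c1ccc(CNc2ccnc(Nc3cccc(NC(=O)N4CCCC4)c3)n2)cc1`: > 10000 nM
Compound 3 `O=C(NCCCNc1nc(Nc2cccc(NC(=O)N3CCCC3)c2)ncc1Br)C1CCC1`: 338 nM

All three were tested in an assay on HEK293 cells for displacement of a labelled ligand from serine/threonine-protein kinase TBK1 (Homo sapiens), read by NanoBRET; a higher number here means a weaker inhibitor, a lower number a stronger inhibitor. For compound 2 the value is a limit of the assay, not a number. Compound 3 stands lowest of the two numbers, with compound 1 as its nearest neighbour an 18-fold lower number from compound 1 to compound 3 (1.26 log units; beyond the scatter). The next compound, compound 4 `O=C(NCCCNc1nc(Nc2cccc(NC(=O)N3CCCC3)c2)ncc1C1CC1)C1CCC1`, differs from compound 3 in one place: cyclopropyl in place of bromo on an aromatic carbon. Among the measured compounds shown here, no measured step swaps bromo for cyclopropyl; the nearest is an at least 1.6-fold higher number from compound 1 to compound 2 (0.20 log units; that floor lies within the scatter), where removing bromo altogether gave only a small change, with one value sitting at the limit of > 10000 nM in this assay, at which 1 of the 3 values shown sits. The cyclopropyl step is therefore expected to stay modest and uncertain in direction, a 1.5-fold higher number from compound 3 to compound 4 (0.17 log units; within the scatter). Compound 4 is estimated at 500 nM, within 150 nM to 2000 nM.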

Compound 4, half-maximal inhibitory concentration: 2580 nM
The estimate for compound 4 lay 5.2-fold (0.71 log units) below the measured number; the measured number lies above the stated range.
By their numbers in this assay, from the lowest: compound 3; then compound 4; then compound 1. At a limit, above all of these: compound 2.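

Replacing bromo with cyclopropyl gives a 7.6-fold higher number from compound 3 to compound 4 (0.88 log units; beyond the scatter) in this assay and so shows that this position is sensitive to the group it carries. The earlier step at the same position, an at least 1.6-fold higher number from compound 1 to compound 2 (0.20 log units; that floor lies within the scatter), could give only a floor, whereas this step lies beyond the scatter. Nothing shown accounts for the gap between bromo and cyclopropyl. Open, going by these compounds, is whether chloro, methyl or a nitrile at this position would match bromo. Also open, on these data alone, is whether cyclopropyl would cost as much alongside the 4-sulfamoylphenyl group of compound 1.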